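Heteroaryl swap on the shared core: thiophene to furan

The compounds below may be only part of what the source reports. "The series", "measured", "known", "first", "only" and "open" are said of these compounds alone.

Measured so far in a functional assay on HCT-15 cells (Homo sapiens) for cytotoxicity, read by CCK-8 assay and cell counting, with a stated time of 2 days; on this read-out higher numbers stand for weaker inhibition and lower numbers for stronger inhibition:
compound 1 `Oc1ccc(-c2cc(-c3cccc(Cl)c3)nc(-c3ccccn3)c2)cc1` gives 28200 nM
compound 2 `Oc1ccc(-c2cc(-c3ccsc3)nc(-c3cccc(Cl)c3)c2)cc1` gives 5760 nM
compound 3 `Oc1cccc(-c2cc(-c3ccsc3)nc(-c3cccc(Cl)c3)c2)c1` gives 2510 nM

Compound 2 stands second highest of the three numbers in this assay; its nearest neighbour is compound 3, reached by a 2.3-fold lower number from compound 2 to compound 3 (0.36 log units; beyond the scatter), and its furthest is compound 1, from which it is reached by a 4.9-fold lower number from compound 1 to compound 2 (0.69 log units; beyond the scatter).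

Compound 4 `Oc1ccc(-c2cc(-c3cccc(Cl)c3)nc(-c3ccco3)c2)cc1` is not yet measured. It differs from compound 2 in one place: furan-2-yl in place of thiophen-3-yl on an aromatic carbon.

Going by the values given here, of the measured steps, only the one from compound 1 to compound 2 touches the same position, and it replaced a six-membered heteroaryl with a five-membered one, with a modest gain. Among the compounds with values here, no step compares two five-membered heteroaryls against each other, so the data give no direct precedent for swapping thiophen-3-yl for furan-2-yl. The step from compound 2 to compound 3 concerns the hydroxyphenyl group and does not bear on this change. With both groups having the same heavy-atom count and one hetero atom each, the expected step is small, in either direction, and likely within the scatter; the estimate is set close to compound 2, leaning slightly weaker.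

Compound 4 is therefore expected to give 7500 nM, with a range from 2500 nM to 22000 nM. That estimate means an expected step of a 1.3-fold higher number from compound 2 to compound 4 (0.11 log units; within the scatter).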

Compound 4, half-maximal inhibitory concentration: 8020 nM
Estimate against measurement, compound 4: 1.1-fold (0.03 log units) below, within the range that was stated.
By their numbers in this assay, from the lowest: compound 3; then compounds 2 and 4 (each within the scatter of the next); then compound 1.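

In this assay, at the place next to the ring nitrogen, the series now holds its first direct comparison of two five-membered heteroaryls: a 1.4-fold higher number from compound 2 to compound 4 (0.14 log units; within the scatter). Furan-2-yl and thiophen-3-yl therefore cannot be told apart on this read-out, even though the hetero atom and the point of attachment both differ between them. Replacing pyridin-2-yl with furan-2-yl gives a 3.5-fold lower number from compound 1 to compound 4 (0.55 log units; beyond the scatter), which, alongside a 4.9-fold lower number from compound 1 to compound 2 (0.69 log units; beyond the scatter), means that two different five-membered groups now stand apart from pyridin-2-yl beyond the scatter, with no compound shown going against this; no measurement accompanying the series speaks to what lies behind these steps.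

The compounds shown leave open how an amine or a carboxylic acid at this place would compare with the five-membered groups and with pyridin-2-yl. They also leave open whether the change from 4-hydroxyphenyl to 3-hydroxyphenyl, which gave a 2.3-fold lower number from compound 2 to compound 3 (0.36 log units; beyond the scatter), would have a similar size with furan-2-yl in place of thiophen-3-yl.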